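This account rests on a few compounds, and the source may have more. Where it says the series, first, only, none or still open, it means among the compounds named here.

Compound 1 `O=C(Nc1ccccc1C(F)(F)F)C1CCc2ccccc2N1` carries a free hydrogen on the ring nitrogen of the shared core. In a functional assay on NCI-H23 cells (Homo sapiens) for cytotoxicity, read by sulforhodamine B assay, with a stated time of 72 h (on this read-out lower numbers stand for stronger inhibition of growth and higher numbers for weaker inhibition of growth), compound 1 gives 56800 nM, the highest of the two numbers shown. Compound 2 `O=C(Nc1ccccc1C(F)(F)F)C1CCc2ccccc2N1C(=O)c1ccc(Cl)cc1` gives 307 nM, so the step of a 190-fold lower number from compound 1 to compound 2 (2.27 log units; beyond the scatter) is large. Compound 3 `CC(=O)N1c2ccccc2CCC1C(=O)Nc1ccccc1C(F)(F)F` returns only a limit, > 80000 nM, and sits at the limit of > 80000 nM in this assay, at which 1 of the 3 values shown sits. The step of an at least 1.4-fold higher number from compound 1 to compound 3 (0.14 log units; that floor lies within the scatter) cannot be read further than that, while the step of an at least 260-fold higher number from compound 2 to compound 3 (2.41 log units; beyond the scatter) is large. All three measured steps concern the ring nitrogen of the core. Compound 4 `O=C(Nc1ccccc1)C1CCc2ccccc2N1` differs from compound 1 at another place: hydrogen in place of trifluoromethyl on an aromatic carbon. Among the compounds with values here, no measured step touches the anilide ring, so the measured steps give no direct guide, and the ring nitrogen of compound 4 stays as in compound 1. Compound 4 is expected to remain close to compound 1, whose value is 56800 nM, with a 1.1-fold higher number from compound 1 to compound 4 (0.02 log units; within the scatter) not beyond the scatter. The estimate for compound 4 in this assay is 60000 nM, between 15000 nM and 200000 nM.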

Compound 4, concentration for 50% growth inhibition: 97100 nM
Estimate against measurement, compound 4: 1.6-fold (0.21 log units) below; measured number inside the range.
By their numbers in this assay, from the lowest: compound 2; then compounds 1 and 4 (each within the scatter of the next).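

In this assay, within the data shown here, replacing trifluoromethyl with hydrogen gives a 1.7-fold higher number from compound 1 to compound 4 (0.23 log units; within the scatter), the first measured change on the anilide ring, so with a free hydrogen on the ring nitrogen the two groups cannot be told apart at this aromatic carbon. The ring nitrogen behaves differently, since adding (4-chlorophenyl)carbonyl there gives a 190-fold lower number from compound 1 to compound 2 (2.27 log units; beyond the scatter), which is beyond the scatter, whereas this change on the anilide ring is not. No data shown here bear on why trifluoromethyl and hydrogen read alike at this position.

The compounds shown leave open whether trifluoromethyl matters once the ring nitrogen carries (4-chlorophenyl)carbonyl, as it does in compound 2. They also leave open how a methoxy group or a nitrile on the same aromatic carbon would read.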